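Hydroxy in place of ring hydrogen on the sugar

The compounds below may be only part of what the source reports. "The series", "measured", "known", "first", "only" and "open" are said of these compounds alone.

Three compounds of the series carry the same core with an alkynyl chain. Compound 1 `CCCCC#Cc1cc2cn([C@@H]3O[C@H](CO)[C@@H](O)[C@H]3O)c(=O)nc2o1` bears a pentynyl chain and a hydroxy on the sugar ring. In a functional assay on HEL cells (Homo sapiens) for cytotoxicity (on this read-out lower numbers stand for higher toxicity in this test and higher numbers for lower toxicity in this test), compound 1 reaches only the limit of the assay, > 144000 nM. Compound 2 `CCCCCCCCCCC#Cc1cc2cn([C@@H]3O[C@H](CO)[C@@H](O)[C@@H]3O)c(=O)nc2o1` carries the undecynyl chain and the other configuration of the hydroxy on the sugar; in this assay compound 2 gives 46000 nM. Compound 3 `CCCCC#Cc1cc2cn([C@H]3C[C@H](O)[C@@H](CO)O3)c(=O)nc2o1` lacks the hydroxy on that saturated ring carbon. In this assay compound 3 also sits at a limit of the assay, > 150000 nM, so among the values shown compound 3 stands with compound 1 at the edge of what the test resolves, and only compound 2 gives a number.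

Compound 4 `CCCCC#Cc1cc2cn([C@@H]3O[C@H](CO)[C@@H](O)[C@@H]3O)c(=O)nc2o1` differs from compound 3 by hydroxy in place of hydrogen on a saturated ring carbon. Among the measured compounds shown here, the only measured step touching this change is a step that the two limits leave unreadable from compound 1 to compound 3, and it is unreadable because both ends rest on limits, the limit of > 144000 nM in this assay, at which 1 of the 3 values shown sits, and (the limit of > 150000 nM in this assay, at which 1 of the 3 values shown sits). No step of the shown compounds therefore gives a direction or a size; the unmeasured step is estimated as a number no higher from compound 3 to compound 4 (the limit leaves the size open), that is, no change beyond the scatter. Compound 4 is expected to give about 150000 nM in this assay, with a range from 50000 nM to 400000 nM, most likely again reported as a limit.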

Compound 4, minimum cytotoxic concentration: > 144000 nM
Compound 4: only a limit was reported; the forecaster's own chance of this, stated with the estimate: 80%; the middle value does not contradict the limit.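

Among the compounds shown here, compound 4 gives the first readable step, and it lies on the chain rather than on the sugar: this assay shows an at least 3.1-fold higher number from compound 2 to compound 4 (0.49 log units; beyond the scatter), with hydrogen in place of hexyl on a saturated chain carbon, four bonds along the chain from a triple-bonded carbon. The steps from compound 3 and from compound 1 to compound 4 cannot be read, since each of them ends on a limit at both sides: the limit of > 144000 nM in this assay, at which 2 of the 4 values shown sit. The hydroxy in place of hydrogen and the change of configuration on the saturated ring carbon therefore still have neither a direction nor a size in this assay, even though the second pair is as close as two compounds can be: the fact that compounds 1 and 4 differ only in the configuration as drawn.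

As far as these compounds go, whether the undecynyl chain of compound 2 would give a readable step for the hydroxy or its configuration on the sugar remains open. Also open is what an amino group in place of that hydroxy, or an octynyl chain between the two chain lengths shown, would give in this assay.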